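Working notes: exchange of the 4-fluoro-2-methoxyphenyl group

The source may report more compounds than this note shows. Statements on the series, on what has been measured and on what is new or still open speak of the compounds shown alone.

In a physicochemical assay for acid dissociation, compound 1 (`CC(C)n1cc(-c2ccnc3[nH]c(C4CCN(CC(=O)N5CCCC5)CC4)cc23)ccc1=O`) gives 7.8 and compound 2 (`COc1cc(F)ccc1-c1ccnc2[nH]c(C3CCN(CC(=O)N(C)C)CC3)cc12`) gives 8 as its reading, which places compound 2 within the scatter of compound 1. Compound 3 (`CC(C)n1cc(-c2ccnc3[nH]c(C4CCN(CC(=O)N(C)C)CC4)cc23)ccc1=O`) awaits measurement. Its change from compound 2 is a group of 10 heavy atoms (8 carbon, 1 nitrogen, 1 oxygen; one six-membered aromatic ring with 1 hetero atom) in place of a group of 9 heavy atoms (7 carbon, 1 oxygen, 1 fluorine; one six-membered aromatic ring of carbon only), on an aromatic carbon on an aromatic carbon of a six-membered aromatic ring with 1 nitrogen, opposite the ring nitrogen. For the measured compounds named here, no measured step isolates this change. Compound 1 at 7.8 and compound 2 at 8 differ in more than one place yet lie within the scatter, so no step beyond the scatter is expected in this assay here. The expected size is a number 0.10 log units lower from compound 2 to compound 3 (within the scatter) and stays within the scatter. Compound 3 is estimated at 7.9 with an expected range of 7.6 to 8.2 for this reading.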

Compound 3, acid dissociation constant: 7.9
Beside the measured number, compound 3's estimate shows no gap at the digits printed, within the range that was stated.
By their numbers in this assay, from the lowest: compounds 1, 3 and 2 (each within the scatter of the next).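

In this assay the exchange of 4-fluoro-2-methoxyphenyl on the aromatic carbon opposite the ring nitrogen gives a number 0.10 log units lower from compound 2 to compound 3 (within the scatter) as an isolated change at this position. Dimethylamino in place of pyrrolidin-1-yl on the carbonyl carbon, also now isolated, gives a number 0.10 log units higher from compound 1 to compound 3 (within the scatter) and so leaves the reading equally undisturbed. Nothing available accounts for either reading.

Going by these compounds, whether an amine or a carboxylic acid opposite the ring nitrogen would move this reading stays open. The same holds for a longer chain in place of dimethylamino on the carbonyl carbon.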